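A few compounds are considered here, and "the series" means these few. Any claim that something is new, unique, unknown or untested is made for them only; others in the source may bear on it.

Measured compounds:
Compound 1 `O=C(Nc1cccc(-n2cc(-c3ccncc3)c(-c3ccc(Cl)c(O)c3)n2)c1)Nc1ccc(Cl)c(Cl)c1`: 1700 nM
Compound 2 `COc1cc(-c2nn(-c3cccc(NC(=O)c4ccccc4)c3)cc2-c2ccncc2)ccc1Cl`: 1330 nM

In a functional assay on BT-549 cells (Homo sapiens) for inhibition, read by sulforhodamine B assay, with a stated time of 48 h (on this read-out higher numbers stand for weaker inhibition of growth and lower numbers for stronger inhibition of growth), compound 1 gives 1700 nM, the higher of the two numbers recorded. Compound 2, with 1330 nM, lies within the usual scatter of that value, so the two cannot be ordered against each other. The unmeasured compound 3 `O=C(Nc1cccc(-n2cc(-c3ccncc3)c(-c3ccc(Cl)c(O)c3)n2)c1)Nc1ccc(Cl)c(C(F)(F)F)c1` is built from compound 1 by a single change, (trifluoromethyl in place of chloro on an aromatic carbon), at a position ortho to a chloro group and meta to a large group. Within the data shown here, no pair of measured compounds shows this exchange, so the expectation for compound 3 rests on compound 1 alone and on the size of change such a swap usually brings. The step of a 1.7-fold lower number from compound 1 to compound 3 (0.23 log units; within the scatter) is expected to be small, at most a modest move toward stronger inhibition, and may well fall within the scatter. Compound 3 is therefore estimated at 1000 nM, with a likely range from 400 nM to 3000 nM.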

Compound 3, concentration for 50% growth inhibition: 1250 nM
Beside the measured number, compound 3's estimate is 1.3-fold (0.10 log units) below it; the measured number falls inside the stated range.
By their numbers in this assay, from the lowest: compounds 3, 2 and 1 (each within the scatter of the next).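

In this assay, trifluoromethyl in place of chloro on an aromatic carbon, ortho to a chloro group and meta to a large group, gives a 1.4-fold lower number from compound 1 to compound 3 (0.13 log units; within the scatter) and so produces no readable change. This single pair therefore shows that the 3,4-dichlorophenyl and 4-chloro-3-(trifluoromethyl)phenyl forms cannot be told apart in this read-out, although the entering group has 4 heavy atoms and the leaving group has 1. No measurement at hand bears on the reason for this result.

As far as these compounds go, whether an amine, a carboxylic acid or a nitrile at this position would give a step beyond the scatter remains open. From the compounds shown here alone, it is also open whether the same exchange would give a similarly small step on the core of compound 2.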